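Benzamido in place of the methylpiperidine amide

The compounds below may be only part of what the source reports. "The series", "measured", "known", "first", "only" and "open" are said of these compounds alone.

Measured in a functional assay on KB cells (Homo sapiens) for antiproliferative activity, read by sulforhodamine B assay, with a stated time of 3 days; on this read-out higher numbers stand for weaker inhibition of growth and lower numbers for stronger inhibition of growth:
compound 1 `O=C(Nc1ccccn1)c1cccc(Nc2ncc(F)c(Nc3ccc(F)cc3)n2)c1`: 20000 nM
compound 2 `O=C(Nc1nccs1)c1cccc(Nc2ncc(F)c(Nc3ccc(F)cc3)n2)c1`: > 10000 nM (a limit of the assay)
compound 3 `CN1CCC(C(=O)Nc2cccc(Nc3ncc(F)c(Nc4ccc(F)cc4)n3)c2)CC1`: 1700 nM

Among the measured compounds shown here, compound 3 holds the lowest number so far, and compound 1 is its nearest neighbour by value. Compound 4 `O=C(Nc1cccc(Nc2ncc(F)c(Nc3ccc(F)cc3)n2)c1)c1ccccc1` differs from compound 3 as follows: phenyl in place of 1-methylpiperidin-4-yl on a carbonyl carbon. For the measured compounds named here, no measured step isolates this change. The closest evidence is a 12-fold lower number from compound 1 to compound 3 (1.07 log units; beyond the scatter) and an at least 5.8-fold lower number from compound 2 to compound 3 (0.76 log units; beyond the scatter), large and at least modest, both reaching the 1-methylpiperidin-4-yl amide from compounds with a second aromatic ring. Losing that group should therefore move the number up in this assay, by a moderate step. The expected step is a 4.1-fold higher number from compound 3 to compound 4 (0.61 log units; beyond the scatter). For compound 4 the estimate is 7000 nM, with an expected range of 2500 nM to 20000 nM.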

Compound 4, concentration for 50% growth inhibition: > 10000 nM
Compound 4 gave a limit, no number (the forecaster's own chance of this, stated with the estimate: 30%); middle value at least 1.4-fold (0.15 log units) from the limit.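

In this assay, phenyl in place of 1-methylpiperidin-4-yl on a carbonyl carbon gives an at least 5.8-fold higher number from compound 3 to compound 4 (0.76 log units; beyond the scatter), the only step shown that isolates this group. Compound 4 reads > 10000 nM, which is a limit and not a number, so this step has no upper size. The steps from compound 1 and from compound 2 to compound 4 cannot be read, and the comparison stops at: the limit of > 10000 nM in this assay, at which 2 of the 4 values shown sit.

Open, going by these compounds, is whether the ring nitrogen of the 1-methylpiperidin-4-yl group or the non-aromatic ring itself carries the difference. A cyclohexyl or an N-H piperidin-4-yl group on the same carbonyl carbon would separate the two.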